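Methyl to Chloro: Expecting the Growth Inhibition of Compound 4

The source may hold more compounds than are shown below. What is called first, only, known or untested is meant among the compounds shown, and "the series" means these compounds.

Of the compounds shown here, three from one series have been tested so far in a functional assay on Jurkat cells (Homo sapiens) for inhibition, read by MTT assay, with a stated time of 72 h; on this read-out lower numbers stand for stronger inhibition of growth and higher numbers for weaker inhibition of growth. Compound 1 `Cc1ccc(-c2nn(-c3cccc(Cl)c3)c(/N=C/N(C)C)c2C=O)cc1` gives 7800 nM in this assay. Compound 2 `CN(C)/C=N/c1c(C=O)c(-c2ccc(Cl)cc2)nn1-c1cccc(Cl)c1` differs from compound 1 only by chloro in place of methyl on an aromatic carbon, and in this assay compound 2 gives 7700 nM. The step between them, a 1.0-fold lower number from compound 1 to compound 2 (0.01 log units; within the scatter), shows that this exchange left growth inhibition essentially unchanged in that pair.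

Compound 3 `Cc1ccc(-c2nn(-c3ccc(Br)cc3)c(N)c2C=O)cc1` belongs to a different core; the difference between the core of compound 3 and the core of compound 1 is not broken down here. In this assay compound 3 gives 34400 nM, the highest number of the three, lying beyond the scatter from both compound 1 and compound 2.

Compound 4 `Nc1c(C=O)c(-c2ccc(Cl)cc2)nn1-c1ccc(Br)cc1` has not yet been measured. It differs from compound 3 by chloro in place of methyl on an aromatic carbon, and the place of the change is described in the same words as for the pair of compound 1 and compound 2, so this is the same change made on a second core. Because that change gave a 1.0-fold lower number from compound 1 to compound 2 (0.01 log units; within the scatter), the step from compound 3 to compound 4 is expected to be similarly small, estimated as a 1.1-fold lower number from compound 3 to compound 4 (0.03 log units; within the scatter). Compound 4 is therefore expected to give about 32000 nM in this assay, with a plausible range from 12000 nM to 85000 nM.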

Compound 4, concentration for 50% growth inhibition: 90700 nM
Estimate against measurement, compound 4: 2.8-fold (0.45 log units) below; measured number above the stated range.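

On the core of compound 3, exchanging 4-methylphenyl for 4-chlorophenyl gave a 2.6-fold higher number from compound 3 to compound 4 (0.42 log units; beyond the scatter) in this assay and so weakened growth inhibition, while the same exchange on the core of compound 1 left growth inhibition essentially unchanged. The effect of this change therefore did not carry over in size from one core to the other: the same change on two cores in this assay, a 1.0-fold lower number (0.01 log units; within the scatter) from compound 1 to compound 2 and a 2.6-fold higher number (0.42 log units; beyond the scatter) from compound 3 to compound 4, 2.7-fold (0.43 log units) apart, beyond the scatter of two such steps

This rests on just one pair of compounds for each core, so it shows only that a flat result on one core did not predict the result on the other, and it does not show which feature of the cores is responsible, as the difference between them is not broken down here, or how the exchange would behave on a further core.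

The compounds shown leave open which part of the core decides the outcome, for instance the free amine of compound 3 set against the larger nitrogen group of compound 1. They also leave open whether the loss seen on the core of compound 3 is particular to chloro, or whether a fluoro, a methoxy or a nitrile in place of the methyl would shift growth inhibition in the same way.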